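This account rests on a few compounds, and the source may have more. Where it says the series, first, only, none or still open, it means among the compounds named here.

Measured compounds, with their values in a functional assay on MOLT-4 cells (Homo sapiens) for inhibition, read by sulforhodamine B assay, with a stated time of 48 h, tested at 10 uM; on this read-out higher numbers stand for more inhibition at the one concentration tested (going by the name of the read-out) and lower numbers for less inhibition:
- compound 1 `O=Cc1ccc(-c2cn3ccnc3c(-c3ccc4ncn(C5CCCCC5)c4c3)n2)cc1`, which gives 58.7%
- compound 2 `O=Cc1ccc(-c2cn3ccnc3c(-c3ccc4ncn(Cc5ccccc5)c4c3)n2)cc1`, which gives 58.7%
- compound 3 `c1cn2cc(-c3ccc4c(c3)ncn4C3CCCCC3)nc(-c3ccc4ncn(C5CCCCC5)c4c3)c2n1`, which gives 56.9%

Compound 1 and compound 2 share one core and differ only in one group: benzyl in place of cyclohexyl on an aromatic nitrogen. That change made the step of no change at the digits printed from compound 1 to compound 2 (within the scatter). Compound 3 carries a different core, and the difference between the two cores is not broken down here; its value is the lowest of the three, but the gaps to compound 1 and compound 2 both lie within the scatter.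

Compound 4 `c1ccc(Cn2cnc3ccc(-c4nc(-c5ccc6c(c5)ncn6C5CCCCC5)cn5ccnc45)cc32)cc1` is built from compound 3 by the same change: benzyl in place of cyclohexyl on an aromatic nitrogen. The surroundings of the place are the same in both pairs. The step from compound 3 to compound 4 is therefore expected to be a number 0.1 percentage points higher from compound 3 to compound 4 (within the scatter), because the matched pair showed no change at the digits printed from compound 1 to compound 2 (within the scatter). Compound 4 is estimated to give 57% in this assay, with a plausible range from 45% to 69%.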

Compound 4, a percentage reported as inhibition, at one concentration (the size of the read-out at that concentration, not a potency): 95.6%
For compound 4 the middle estimate is 38.6 percentage points below the measured one; measured number outside the range, above it.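

In this assay, benzyl in place of cyclohexyl on an aromatic nitrogen gave a number 38.7 percentage points higher from compound 3 to compound 4 (beyond the scatter) and did not behave the same way on the two cores: the same change on two cores in this assay, no change at the digits printed (within the scatter) from compound 1 to compound 2 and a number 38.7 percentage points higher (beyond the scatter) from compound 3 to compound 4, 38.7 percentage points apart, beyond the scatter of two such steps

A step measured on one core is therefore no safe guide to the same step on the other core in this series. These two pairs do not show why the cores differ, and the read-out, taken at one concentration, gives the size of the inhibition and not a potency.

The compounds shown leave open what a second benzyl in place of the remaining cyclohexyl of compound 4 would do. They also leave open how a small methyl or a longer phenylethyl chain on the same nitrogen would compare.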